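Trading a Methoxy for a Hydroxy at the Limit

A few compounds are considered here, and "the series" means these few. Any claim that something is new, unique, unknown or untested is made for them only; others in the source may bear on it.

Of the compounds shown here, three built on one shared core have been tested in a functional assay on SW-620 cells (Homo sapiens) for inhibition, read by sulforhodamine B assay, with a stated time of 48 h; a lower number here means that less compound is tolerated, a higher number that more compound is tolerated. Compound 1 `COc1cc(C)cc(-c2c(-c3ccnc(-c4ccc(C(C)=O)cc4)c3)cnn2CC#N)c1` gives only a limit of the assay, > 100000 nM. Compound 2 `Cc1cc(O)cc(-c2nn(CC#N)cc2-c2ccnc(-c3ccc(Oc4ccccc4)cc3)c2)c1` gives a number, 9630 nM. Compound 3 `COc1cc(C)cc(-c2nn(CC#N)cc2-c2ccnc(-c3ccc(N(C)C)cc3)c2)c1` also stops at a limit, > 100000 nM. Compound 3 therefore stands where the assay reports no number at all: the limit of > 100000 nM in this assay, at which 2 of the 3 values shown sit. Among the compounds with values here, no pair of measured compounds differs in just one place, so no measured step is available to anchor it.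

Compound 4 `Cc1cc(O)cc(-c2nn(CC#N)cc2-c2ccnc(-c3ccc(N(C)C)cc3)c2)c1` differs from compound 3 in one place: hydrogen in place of methyl on an oxygen on an aromatic ring. Within the data shown here, compound 2 carries the same hydroxy group and returns a number, whereas compound 1 and compound 3 carry the methoxy and return limits, but each of those pairs also differs elsewhere, so they show no single step. A move out of the limit is expected for compound 4, though with wide uncertainty. The step of an at least 1.6-fold lower number from compound 3 to compound 4 (0.22 log units; that floor lies within the scatter) is expected to be modest in this assay. Compound 4 is estimated at 60000 nM, between 10000 nM and 300000 nM.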

Compound 4, concentration lethal to 50% of the cells: > 100000 nM
Compound 4 ended at the assay's limit; the forecaster's own chance of this, stated with the estimate: 55%; at least 1.6-fold (0.22 log units) between middle value and limit.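

In this assay, compound 3 and compound 4 both stop at a limit of the assay, so the change from methoxy to hydroxy cannot be read, and the hydroxy group on its own does not yield a number here. With the hydroxy group held in place, dimethylamino in place of phenoxy on an aromatic carbon gives an at least 10-fold higher number from compound 2 to compound 4 (1.01 log units; beyond the scatter), so among these compounds the only number goes with phenoxy rather than with hydroxy alone. Most of the set now sits at a single ceiling: the limit of > 100000 nM in this assay, at which 3 of the 4 values shown sit.

The compounds shown leave open whether phenoxy paired with methoxy would also give a number. They also leave open whether a benzyloxy group or a morpholine in the place of phenoxy would bring the hydroxy compounds down from the limit.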